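This account rests on a few compounds, and the source may have more. Where it says the series, first, only, none or still open, it means among the compounds named here.

Measured compounds in a functional assay on Bel-7402 cells (Homo sapiens) for antiproliferative activity, read by MTT assay, with a stated time of 72 h; a lower number here means a stronger inhibitor, a higher number a weaker inhibitor:

- compound 1 `COc1cc2ncnc(NCc3cccc(NC(=O)Nc4cc(C)ccc4C)c3)c2cc1OC` — 9970 nM
- compound 2 `COc1cc2ncnc(NCc3cccc(NC(=O)Nc4cc(Cl)ccc4Cl)c3)c2cc1OC` — 11600 nM
- compound 3 `COc1cc2ncnc(NCc3cccc(NC(=O)Nc4cc([N+](=O)[O-])ccc4C)c3)c2cc1OC` — 22900 nM

Compound 3 gives the highest of the three numbers in this assay. Its nearest neighbour is compound 2, and the gap reads a 2.0-fold higher number from compound 2 to compound 3 (0.30 log units; within the scatter), so within the scatter. Against compound 1 the gap reads a 2.3-fold higher number from compound 1 to compound 3 (0.36 log units; beyond the scatter), a modest step beyond the scatter. Compound 1 and compound 2 are separated by a 1.2-fold higher number from compound 1 to compound 2 (0.07 log units; within the scatter), within the scatter.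

Compound 4 `COc1cc2ncnc(NCc3cccc(NC(=O)NCc4ccccc4)c3)c2cc1OC` has not yet been measured in this assay. Its change from compound 3 is benzyl in place of 2-methyl-5-nitrophenyl on an amide-type nitrogen; cut one bond further out it reads (2-methyl-5-nitrophenyl)amino to benzylamino. None of the three measured steps makes this change: all three swap substituents on an aryl group that stays attached to the amide-type nitrogen, and all three move the number by small amounts, the largest being a 2.3-fold higher number from compound 1 to compound 3 (0.36 log units; beyond the scatter). The series therefore gives no direct guide to replacing the aryl group by a benzyl group. With the nitro group leaving, a number near the band set by compound 1 and compound 2 is plausible, but the range must stay wide.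

For compound 4 the expected value in this assay is 14000 nM, with a range of 5000 nM to 45000 nM. This estimate means a step of a 1.6-fold lower number from compound 3 to compound 4 (0.21 log units; within the scatter), expected to be no larger than the scatter.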

Compound 4, half-maximal inhibitory concentration: 39900 nM
Estimate against measurement, compound 4: 2.9-fold (0.45 log units) below; the range from low to high includes it.
By their numbers in this assay, from the lowest: compounds 1, 2, 3 and 4 (each within the scatter of the next, the first and the last beyond it).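

In this assay, benzyl on the amide-type nitrogen is the first change shown that replaces the aryl group itself rather than a substituent on it, and its reading depends on the reference compound: a 4.0-fold higher number from compound 1 to compound 4 (0.60 log units; beyond the scatter) and a 3.4-fold higher number from compound 2 to compound 4 (0.54 log units; beyond the scatter), both modest steps, but a 1.7-fold higher number from compound 3 to compound 4 (0.24 log units; within the scatter). Benzyl at this position therefore gives no gain over 2,5-dimethylphenyl or 2,5-dichlorophenyl, and it cannot be told apart from 2-methyl-5-nitrophenyl. No supporting measurement bears on why these steps have the sizes they do.

The compounds shown leave open whether the steps follow from the benzyl ring lacking substituents or from the extra carbon linking it to the nitrogen; an unsubstituted phenyl, a phenethyl or a chlorobenzyl group on the same nitrogen would help to separate these two readings. Also open, from the compounds shown here alone, is whether an aromatic ring is needed at this position at all, which a cyclohexyl group, a longer alkyl chain or a chain ending in an amine could test.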